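The source may report more compounds than this note shows. Statements on the series, on what has been measured and on what is new or still open speak of the compounds shown alone.

The compounds share one core, varied at two places. Compound 2 `Cc1cc(CCC#N)cc(C)c1Oc1cc(Nc2ccc(C#N)cc2)c(N)cc1C(N)=O` carries a 2-cyanoethyl chain and an unsubstituted carboxamide, and in a physicochemical assay for lipophilicity, at pH 7.4 (on this read-out higher numbers stand for higher lipophilicity and lower numbers for lower lipophilicity), compound 2 gives 2.65. Among the compounds with values here, compound 3 `CNC(=O)c1cc(N)c(Nc2ccc(C#N)cc2)cc1Oc1c(C)cc(CCC#N)cc1C` differs from it by methyl in place of hydrogen on an amide-type nitrogen, and in this assay compound 3 gives 2.65; that step, no change at the digits printed from compound 2 to compound 3 (within the scatter), is the only one measured between two numbers here. Compound 1 `Cc1cc(/C=C/C#N)cc(C)c1Oc1cc(Nc2ccc(C#N)cc2)c(N)cc1C(F)(F)F` carries the 2-cyanoethenyl chain together with a trifluoromethyl group. In this assay compound 1 reaches the limit > 5, which is a limit of the assay and not a number (the limit of > 5 in this assay, at which 1 of the 3 values shown sits). Within the data shown here, compound 2 therefore stands level with compound 3 within the scatter, and the one further value is a limit.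

Compound 4 `Cc1cc(/C=C/C#N)cc(C)c1Oc1cc(Nc2ccc(C#N)cc2)c(N)cc1C(N)=O` is reached from compound 2 by the change (2-cyanoethenyl in place of 2-cyanoethyl on an aromatic carbon). Among the measured compounds shown here, no measured step concerns this change: the step from compound 2 to compound 3 alters a different place, and compound 1 differs from compound 4 in a second place as well, with its value a limit. Without a measured guide, the expectation for compound 4 is a small rise, estimated as a number 0.25 log units higher from compound 2 to compound 4 (within the scatter), within or just beyond the scatter. Compound 4 is thus expected to give 2.9 in this assay, in the range from 2.5 to 3.3.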

Compound 4, partition coefficient: 3.53
Beside the measured number, compound 4's estimate is 0.63 log units below it; the measured number lies above the stated range.
By their numbers in this assay, from the lowest: compounds 2 and 3 (each within the scatter of the next); then compound 4. At a limit, above all of these: compound 1.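

The chain para to a large group turns out to be a place where the read-out moves: in this assay, 2-cyanoethenyl in place of 2-cyanoethyl gives a number 0.88 log units higher from compound 2 to compound 4 (beyond the scatter), although the two chains have the same count of heavy atoms and differ by one double bond. With the 2-cyanoethenyl chain held constant, the second varied place also moves the read-out, since carbamoyl in place of trifluoromethyl gives a number at least 1.47 log units lower from compound 1 to compound 4 (beyond the scatter). The value of compound 1 is a limit and not a number, so this step gives only a bound on the size of the change: the limit of > 5 in this assay, at which 1 of the 4 values shown sits.

The compounds shown leave open whether the same change of chain gives a similar rise with a trifluoromethyl group or with the methyl-substituted amide of compound 3 in place of the unsubstituted carboxamide. They also do not show where a longer chain, or an amine or a carboxylic acid in place of the nitrile, would fall in this assay, and they offer no measured reason for the size of the rise.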